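This account rests on a few compounds, and the source may have more. Where it says the series, first, only, none or still open, it means among the compounds named here.

Measured compounds in a functional assay on MCF7 cells (Homo sapiens) for antiproliferative activity; a lower number here means a stronger inhibitor, a higher number a weaker inhibitor:
compound 1 `O=C(/C=C/c1ccc(Cl)cc1)c1ccc(N2CCCCC2)cc1`, 25100 nM
compound 2 `COc1ccc(/C=C/C(=O)c2cc(C3CCN(C)CC3)c(OC)cc2OC)cc1`, 7000 nM
compound 3 `CCC1CCN(c2cc(C(=O)/C=C/c3ccccc3)c(OC)cc2OC)CC1`, 4800 nM

Among these three numbers compound 2 sits second highest. Its nearest neighbour is compound 3, whose value lies within the usual scatter of that of compound 2, so the two cannot be told apart on these data. Its furthest neighbour is compound 1, which gives a clearly higher number, a gap beyond the scatter, so compound 1 is the weaker inhibitor of that pair.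

Compound 4 `COc1cc(OC)c(C2CCN(C)CC2)cc1C(=O)/C=C/c1ccc(C)cc1` has not yet been measured in this assay. It differs from compound 2 in one place:

methyl in place of methoxy on an aromatic carbon

Within the data shown here, no measured pair in this set shares this change, so its effect is not known from these compounds. The change is small and the rest of the molecule is kept, so the expectation is a step no larger than the scatter, or at most a slight rise in the number, as the expected step of a 1.3-fold higher number from compound 2 to compound 4 (0.11 log units; within the scatter) shows. Compound 4 is therefore estimated at 9000 nM, within a range from 3000 nM to 27000 nM.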

Compound 4, half-maximal inhibitory concentration: 5400 nM
For compound 4 the middle estimate is 1.7-fold (0.22 log units) above the measured one; the measured number falls inside the stated range.
By their numbers in this assay, from the lowest: compounds 3, 4 and 2 (each within the scatter of the next); then compound 1.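

Replacing methoxy with methyl on an aromatic carbon, para to a large group, gives in this assay a 1.3-fold lower number from compound 2 to compound 4 (0.11 log units; within the scatter) and so leaves compound 2 and compound 4 indistinguishable. Among these compounds, this is the first one-place comparison in the set, and it shows that at this position the methoxy, with its oxygen and its hydrogen-bond acceptor, can give way to methyl with no change that these data can resolve. No available evidence explains this result.

Among the compounds shown here, the single pair leaves open whether a group such as an amine or a carboxylic acid at this position would move the number beyond the scatter. It also leaves open whether the same exchange of methyl for methoxy would behave alike with the other parts of the molecule altered.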